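Methyl for trifluoromethyl: compound 3 to compound 4

The source may hold more compounds than are shown below. What is called first, only, known or untested is meant among the compounds shown, and "the series" means these compounds.

Compound 3 `O=C(Nc1ccc(Oc2ccnc3[nH]ccc23)cc1)c1cc(-c2ccc(C(F)(F)F)cc2)ncn1` gives 9380 nM in a functional assay on A549 cells (Homo sapiens) for cytotoxicity, read by MTT assay, with a stated time of 72 h (a higher number here means a weaker inhibitor, a lower number a stronger inhibitor), the highest of the three numbers measured. Compound 2 `COc1ccc(-c2cc(C(=O)Nc3ccc(Oc4ccnc5[nH]ccc45)cc3)ncn2)cc1` gives 4410 nM in this assay, and compound 1 `Cc1ccc(-c2ccnc(C(=O)Nc3ccc(Oc4ccnc5[nH]ccc45)cc3)n2)cc1` gives 2380 nM. Compound 4 `Cc1ccc(-c2cc(C(=O)Nc3ccc(Oc4ccnc5[nH]ccc45)cc3)ncn2)cc1` differs from compound 3 by methyl in place of trifluoromethyl on an aromatic carbon. Among the compounds with values here, the one measured step that bears on this change is a 2.1-fold higher number from compound 2 to compound 3 (0.33 log units; beyond the scatter), a modest rise on entering trifluoromethyl. Within the data shown here, no measured pair sets methyl directly against trifluoromethyl; compound 1, which carries methyl on a different core, shows 2380 nM, whereas compound 3 shows 9380 nM. Because a 2.1-fold higher number from compound 2 to compound 3 (0.33 log units; beyond the scatter) was modest, the reverse change is expected to lower the number by a similar amount. Compound 4 is expected to give 3500 nM in this assay, within 1500 nM to 8000 nM. The expected step is a 2.7-fold lower number from compound 3 to compound 4 (0.43 log units; beyond the scatter).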

Compound 4, half-maximal inhibitory concentration: 5410 nM
Compound 4: middle estimate off by 1.5-fold (0.19 log units), on the low side; low and high end bracket the measured number.
By their numbers in this assay, from the lowest: compounds 1, 2, 4 and 3 (each within the scatter of the next, the first and the last beyond it).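

In this assay the direct pair at this position gives a 1.7-fold lower number from compound 3 to compound 4 (0.24 log units; within the scatter) and so does not separate methyl from trifluoromethyl. Methyl against methoxy gives a 1.2-fold higher number from compound 2 to compound 4 (0.09 log units; within the scatter) and does not separate those two groups either, which leaves only the methoxy and trifluoromethyl pair of compound 2 and compound 3 apart beyond the scatter. No evidence is at hand that bears on these steps. Going by these compounds, whether an amine, a carboxylic acid or a longer chain at this position would give a step beyond the scatter stays open. On these data alone, whether methyl and trifluoromethyl also stay together on the core of compound 1 stays open too.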